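Shortening a Side Chain in a Cytotoxicity Series

This account rests on a few compounds, and the source may have more. Where it says the series, first, only, none or still open, it means among the compounds named here.

In a functional assay on DU-145 cells (Homo sapiens) for cytotoxicity, read by MTT assay (on this read-out higher numbers stand for weaker inhibition and lower numbers for stronger inhibition), the measured compounds are:
Compound 1 `CC(C)C[C@@H](NC(=S)Nc1ccccc1)c1nc2ccccc2[nH]1` gives 20000 nM
Compound 2 `C[C@H](NC(=S)Nc1cc(C(F)(F)F)cc(C(F)(F)F)c1)c1nc2ccccc2[nH]1` gives 154000 nM
Compound 3 `CC(C)C[C@H](NC(=S)Nc1ccccc1)c1nc2ccccc2[nH]1` gives 28900 nM

Compound 3 holds the second highest of the three numbers; compound 1 is nearest, separated by a 1.4-fold higher number from compound 1 to compound 3 (0.16 log units; within the scatter), and compound 2 stands furthest away with the higher number. Compound 4 `C[C@H](NC(=S)Nc1ccccc1)c1nc2ccccc2[nH]1` differs from compound 3 by hydrogen in place of isopropyl on a saturated chain carbon, two bonds along the chain from an amide-type nitrogen and an aromatic carbon, isobutyl becoming methyl. For the measured compounds named here, no measured step touches this side chain: the only measured step, a 1.4-fold higher number from compound 1 to compound 3 (0.16 log units; within the scatter), concerns configuration alone, as the fact that compounds 1 and 3 differ only in the configuration as drawn shows. Compound 2 also carries the methyl, alongside two trifluoromethyl groups, so its value shows only a higher number. Compound 4 is therefore expected to give 45000 nM, between 15000 nM and 130000 nM. The expected step is a 1.6-fold higher number from compound 3 to compound 4 (0.19 log units; within the scatter), a loosely anchored, modest rise.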

Compound 4, half-maximal inhibitory concentration: "not active" (no number reported)
For compound 4 the study gives words and no number; the estimate stays without a comparison.
By their numbers in this assay, from the lowest: compounds 1 and 3 (each within the scatter of the next); then compound 2.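

For the compounds shown here, for compound 4 the study gives only the words "not active", so no step from compound 3 to compound 4 can be read. As far as these compounds go, what the change from isobutyl to methyl does to the value on this shared core stays open. Nothing at hand bears on this result.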